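A few compounds are considered here, and "the series" means these few. Any claim that something is new, unique, unknown or untested is made for them only; others in the source may bear on it.

In an assay for inhibition of 3-hydroxy-3-methylglutaryl-coenzyme A reductase (Rattus norvegicus), using microsomes (a higher number here means a weaker inhibitor, a lower number a stronger inhibitor), the two measured compounds stand as follows:
Compound 1 `COC(=O)C[C@H](O)C[C@H](O)/C=C/n1c(C(C)C)cc(-c2ccc(F)cc2)c1-c1ccccc1` gives 25 nM.
Compound 2 `COC(=O)C[C@H](O)C[C@H](O)/C=C/n1c(C(C)C)cc(-c2ccc(F)cc2)c1-c1cccc(Br)c1` gives 69 nM.

Compound 2 thus has the higher of the two numbers, separated from compound 1 by a 2.8-fold higher number from compound 1 to compound 2 (0.44 log units; beyond the scatter). Compound 3 `COC(=O)C[C@H](O)C[C@H](O)/C=C/n1c(C(C)C)cc(-c2ccc(F)cc2)c1-c1ccc(F)cc1` differs from compound 2 by 4-fluorophenyl in place of 3-bromophenyl on an aromatic carbon. Going by the values given here, no measured step involves fluorine at this place; the only step that bears on the change, a 2.8-fold higher number from compound 1 to compound 2 (0.44 log units; beyond the scatter), shows a higher number when bromine enters in place of hydrogen, so taking bromine out again is expected to bring the number back toward compound 1 and its 25 nM. Compound 3 is therefore expected at about 30 nM, within 12 nM to 75 nM, a step of a 2.3-fold lower number from compound 2 to compound 3 (0.36 log units; beyond the scatter).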

Compound 3, half-maximal inhibitory concentration: 2 nM
For compound 3 the middle estimate is 15-fold (1.18 log units) above the measured one; measured number below the stated range.
By their numbers in this assay, from the lowest: compound 3; then compound 1; then compound 2.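

In this assay, this position proves far more sensitive than the bromo step alone suggested (a 35-fold lower number from compound 2 to compound 3 (1.54 log units; beyond the scatter)). Fluoro in place of hydrogen moves the number the opposite way from bromo in place of hydrogen (a 13-fold lower number from compound 1 to compound 3 (1.10 log units; beyond the scatter)), so a halogen on this phenyl ring does not always raise it, although 4-fluorophenyl and 3-bromophenyl also carry their halogens at different ring places. No available evidence gives a reason for this large drop.

As far as these compounds go, whether the halogen or its ring place matters more stays open: 3-fluorophenyl or 4-bromophenyl would separate the two. From the compounds shown here alone, how 4-methoxyphenyl or 4-aminophenyl would behave here also remains unknown.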